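The compounds below may be only part of what the source reports. "The series", "measured", "known", "first", "only" and "open" are said of these compounds alone.

Measured in an assay on membranes from liver for displacement of a labelled ligand from Sigma intracellular receptor 2 (Rattus norvegicus), read by scintillation counting, with a stated time of 120 min; a lower number here means a stronger inhibitor, a higher number a weaker inhibitor:

Compound 1, `COc1cc2c(cc1OC)CN(CCCC(=O)c1c(C)c(OC)c(OC)c(OC)c1OC)CC2`: 5.1 nM
Compound 2, `COc1cc2c(c(OC)c1OC)CCN(CCCC(=O)c1c(C)c(OC)c(OC)c(OC)c1OC)C2`: 41.8 nM
Compound 3, `COc1cc2c(cc1OC)CN(CCCCCCC(=O)c1c(C)c(OC)c(OC)c(OC)c1OC)CC2`: 1.33 nM

Compound 2 differs from compound 1 by one change, (methoxy in place of hydrogen on an aromatic carbon), and that change produced an 8.2-fold higher number from compound 1 to compound 2 (0.91 log units; beyond the scatter). Compound 3 has the lowest number of the three; how its core differs from the core of compound 1 is not broken down here. Compound 4, `COc1cc2c(c(OC)c1OC)CN(CCCCCCC(=O)c1c(C)c(OC)c(OC)c(OC)c1OC)CC2`, has not yet been measured. It differs from compound 3 by the same change, (methoxy in place of hydrogen on an aromatic carbon), made at the same kind of place on the ring. Because the earlier instance of this change gave an 8.2-fold higher number from compound 1 to compound 2 (0.91 log units; beyond the scatter), a step of similar size is expected from compound 3 to compound 4, namely an 8.3-fold higher number from compound 3 to compound 4 (0.92 log units; beyond the scatter). Compound 4 is therefore estimated at 11 nM in this assay, most likely between 4.5 nM and 28 nM.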

Compound 4, inhibition constant: > 1000 nM
Compound 4 gave a limit, no number; the forecaster's own chance of this, stated with the estimate: 2%; middle value at least 90-fold (1.95 log units) from the limit.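

In this assay, compound 4 gives > 1000 nM, which is a limit of the assay and not a number. Adding the methoxy group gave an at least 750-fold higher number from compound 3 to compound 4 (2.87 log units; beyond the scatter), so the change did not carry over at the same size from one core to the other: the same change on two cores in this assay, an 8.2-fold higher number (0.91 log units; beyond the scatter) from compound 1 to compound 2 and an at least 750-fold higher number (2.87 log units; beyond the scatter) from compound 3 to compound 4, at least 91-fold (1.96 log units) apart, beyond the scatter of two such steps. Going by these compounds, the number went up on both cores, but the true size of the second step stays unknown, and two pairs cannot show what sets the two steps apart.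

The compounds shown leave open what a smaller or different group at the same place, such as a hydroxyl group or a chlorine atom, would do on each core. They also leave open how this methoxy change behaves on further cores.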